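The compounds below may be only part of what the source reports. "The series", "measured", "known", "first", "only" and "open" are said of these compounds alone.

Compound 1 `CCOC(=O)c1cc(-c2cc(OC)c(OC)c(OC)c2)c(-c2ccc(OC)c([N+](=O)[O-])c2)s1` is the reference point of the series; in a functional assay on HT-1080 cells (Homo sapiens) for antiproliferative activity, read by MTT assay, with a stated time of 72 h (a lower number here means a stronger inhibitor, a higher number a weaker inhibitor), compound 1 gives 12700 nM. Compound 2 `CCOC(=O)c1cc(-c2cc(OC)c(OC)c(OC)c2)c(-c2ccc(OC)c(OCc3ccccc3)c2)s1` differs from compound 1 by benzyloxy in place of nitro on an aromatic carbon. In this assay compound 2 gives only a limit, > 100000 nM. The step is thus an at least 7.8-fold higher number from compound 1 to compound 2 (0.89 log units; beyond the scatter), with the value of compound 2 sitting at the limit of > 100000 nM in this assay, at which 1 of the 3 values shown sits. Compound 3 `COc1ccc(-c2sc(C(=O)O)cc2-c2cc(OC)c(OC)c(OC)c2)cc1[N+](=O)[O-]` is the carboxy counterpart of compound 1; in this assay compound 3 gives 37200 nM, a step of a 2.9-fold higher number from compound 1 to compound 3 (0.47 log units; beyond the scatter). Of the two plain numbers, compound 3 stands highest, with compound 1 nearest to it.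

Compound 4 `COc1ccc(-c2sc(C(=O)O)cc2-c2cc(OC)c(OC)c(OC)c2)cc1OCc1ccccc1` has not yet been measured in this assay. It differs from compound 3 by benzyloxy in place of nitro on an aromatic carbon. The surroundings of the place read the same, word for word, as for the change from compound 1 to compound 2, so this is the same change, made on a different core; the two cores differ by hydrogen in place of ethyl on an oxygen next to a carbonyl group. Since the same change has already been made once, the expectation rests on compound 1 and compound 2 and on the step of an at least 7.8-fold higher number from compound 1 to compound 2 (0.89 log units; beyond the scatter), which was only a limit-bound step. From compound 3 to compound 4 a step of about a 6.7-fold higher number from compound 3 to compound 4 (0.83 log units; beyond the scatter) is expected, set beside the earlier one. Compound 4 is accordingly expected to give 250000 nM, most likely reported again only as a limit, with an estimated range from 100000 nM to 700000 nM.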

Compound 4, half-maximal inhibitory concentration: > 100000 nM
Compound 4: only a limit was reported; the forecaster's own chance of this, stated with the estimate: 75%; the middle value does not contradict the limit.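

In this assay compound 4 gives only a limit, > 100000 nM. Benzyloxy in place of nitro raises the number on the carboxy core as well, with an at least 2.6-fold higher number from compound 3 to compound 4 (0.42 log units; beyond the scatter), so the direction of the change carries over from the core of compound 1 to the core of compound 3: the same change on two cores in this assay, an at least 7.8-fold higher number (0.89 log units; beyond the scatter) from compound 1 to compound 2 and an at least 2.6-fold higher number (0.42 log units; beyond the scatter) from compound 3 to compound 4; the limit leaves it open whether they differ. As far as these compounds go, the true size of the change remains unknown on both cores, and the step between the two limit compounds, compound 2 and compound 4, cannot be read, so these data do not show whether the ethyl ester and the carboxylic acid differ once benzyloxy is present: the limit of > 100000 nM in this assay, at which 2 of the 4 values shown sit.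

Among the compounds shown, only nitro and benzyloxy occupy this place, so it stays open how an amine or a hydroxy group there would read on either core. Also open, from the compounds shown here alone, is whether the higher number seen on going from ester to acid with nitro in place, a 2.9-fold higher number from compound 1 to compound 3 (0.47 log units; beyond the scatter), holds for any other group at this position, since the benzyloxy pair offers no readable comparison.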